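Chain Unsaturation and Antiproliferative Potency

This account rests on a few compounds, and the source may have more. Where it says the series, first, only, none or still open, it means among the compounds named here.

In a functional assay on MDA-MB-231 cells (Homo sapiens) for antiproliferative activity, read by MTT assay (a lower number here means a stronger inhibitor, a higher number a weaker inhibitor), the measured compounds give these numbers
Compound 1 `CC/C=C\C/C=C\C/C=C\CCCCCCCC1(O)CC(=O)c2c(O)cc(OCOC)cc2O1` gives 6790 nM
Compound 2 `CCCC/C=C\CCCCCCCCCC1(O)CC(=O)c2c(O)cc(OCOC)cc2O1` gives 42800 nM

Compound 2 has the higher of the two numbers, so it is the weaker inhibitor so far. Compound 3 `CCCCC/C=C\C/C=C\CCCCCCCC1(O)CC(=O)c2c(O)cc(OCOC)cc2O1` differs from it in one place, and the change deca-1,4-dien-1-yl in place of oct-3-en-1-yl on a saturated chain carbon, seven bonds along the chain from a saturated ring carbon lies on a saturated chain carbon, seven bonds along the chain from a saturated ring carbon. Going by the values given here, only one measured step bears on this, and it also ends on the oct-3-en-1-yl chain. That step is a 6.3-fold higher number from compound 1 to compound 2 (0.80 log units; beyond the scatter) and it is modest but beyond the scatter. Among the compounds with values here, with one step as the only guide, compound 3 is expected to give a lower number than compound 2 in this assay by only part of that size. The expected change is a 2.9-fold lower number from compound 2 to compound 3 (0.46 log units; beyond the scatter) and it remains an estimate. Compound 3 is estimated at 15000 nM within a range of 6000 nM to 38000 nM as its expected span.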

Compound 3, half-maximal inhibitory concentration: 16100 nM
Beside the measured number, compound 3's estimate is 1.1-fold (0.03 log units) below it, and the stated range covers the measured number.
By their numbers in this assay, from the lowest: compound 1; then compound 3; then compound 2.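

In this assay, deca-1,4-dien-1-yl in place of oct-3-en-1-yl gives a 2.7-fold lower number from compound 2 to compound 3 (0.42 log units; beyond the scatter), so the chain can be changed at this position in a way that recovers part of the gap to compound 1, though that swap alters chain length and the count of double bonds together. Butyl in place of but-1-en-1-yl gives a 2.4-fold higher number from compound 1 to compound 3 (0.37 log units; beyond the scatter), which is the cleaner comparison: the chain keeps its length and loses a double bond near its end, and the number still rises beyond the scatter. No measurement here explains why these chain changes shift the number.

From the compounds shown here alone, how much of the step to compound 3 comes from the added carbons and how much from the second double bond remains open. Also open, going by these compounds, is how a fully saturated chain, or a carboxylic acid at the chain end, would compare.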